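Imidazole in place of pyridine: notes on the series

The compounds below may be only part of what the source reports. "The series", "measured", "known", "first", "only" and "open" are said of these compounds alone.

Values in a functional assay on NCI-H460 cells (Homo sapiens) for cytotoxicity, read by MTT assay, with a stated time of 72 h; on this read-out higher numbers stand for weaker inhibition and lower numbers for stronger inhibition:
- compound 1 `CC(C)(C)c1[nH]cnc1/C=c1\[nH]c(=O)/c(=C/c2cccc(Oc3ccc(F)cc3)c2)[nH]c1=O`: 4 nM
- compound 2 `CC(C)c1[nH]cnc1/C=c1\[nH]c(=O)/c(=C/c2cccc(Oc3ccc(F)cc3)c2)[nH]c1=O`: 8.8 nM
- compound 3 `O=c1[nH]/c(=C\c2cccc(Oc3ccc(F)cc3)c2)c(=O)[nH]/c1=C\c1cccnc1`: > 1000 nM (a limit, not a number)

Compound 3 stands at the limit of > 1000 nM in this assay, at which 1 of the 3 values shown sits, so the starting point is a limit only. Compound 4 `O=c1[nH]/c(=C\c2ncc[nH]2)c(=O)[nH]/c1=C\c1cccc(Oc2ccc(F)cc2)c1` is next, and its change from compound 3 is 1H-imidazol-2-yl in place of pyridin-3-yl on a double-bonded chain carbon bound to an aromatic carbon. Within the data shown here, three measured steps bear on it. Pyridin-3-yl in place of the alkyl-bearing imidazolyl groups gave an at least 250-fold higher number from compound 1 to compound 3 (2.39 log units; beyond the scatter) and an at least 110-fold higher number from compound 2 to compound 3 (2.05 log units; beyond the scatter), both large. Hydrogen in place of methyl gave only a 2.2-fold higher number from compound 1 to compound 2 (0.34 log units; beyond the scatter). Among the measured compounds shown here, compound 4 regains an imidazolyl group but carries neither the tert-butyl nor the isopropyl group, and no measured step covers that loss. Only part of the large loss is therefore expected to return, as a move to a lower number in this assay, and a second limit remains possible. The expected step is an at least 2.5-fold lower number from compound 3 to compound 4 (0.39 log units; beyond the scatter). The estimate for compound 4 is 400 nM, with an expected range of 50 nM to 2500 nM.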

Compound 4, half-maximal inhibitory concentration: > 1000 nM
Compound 4 gave a limit, no number; the forecaster's own chance of this, stated with the estimate: 35%; middle value at least 2.5-fold (0.39 log units) from the limit.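

In this assay compound 4 gives > 1000 nM, a limit and not a number, and it shares that limit with compound 3, so the step between them cannot be read: the limit of > 1000 nM in this assay, at which 2 of the 4 values shown sit. The 1H-imidazol-2-yl group, on a double-bonded chain carbon bound to an aromatic carbon, does not restore the values of the alkyl-bearing imidazolyl compounds, with an at least 110-fold higher number from compound 2 to compound 4 (2.05 log units; beyond the scatter) and an at least 250-fold higher number from compound 1 to compound 4 (2.39 log units; beyond the scatter), both large. An imidazolyl group at this position is therefore not sufficient on its own, which compound 3 could not show.

Compound 4 differs from compound 1 and compound 2 both in the imidazole attachment and in the missing alkyl group, and these two changes remain unseparated. Open too, as far as these compounds go, is how a 1H-imidazol-4-yl group would behave here with only hydrogen or a methyl group in place of the tert-butyl or isopropyl group.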